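A few compounds are considered here, and "the series" means these few. Any claim that something is new, unique, unknown or untested is made for them only; others in the source may bear on it.

Measured so far, in an assay on CHO-K1 cells for antagonist activity at transient receptor potential cation channel subfamily V member 1 (Homo sapiens), read by FLIPR and calcium flux, with a stated time of 6 min; on this read-out higher numbers stand for weaker inhibition and lower numbers for stronger inhibition:

compound 1, `CC(C)(C)c1cc(CNC(=O)Nc2cccc3[nH]ncc23)n(-c2cccc(F)c2)n1`, gives 1.3 nM
compound 2, `CC(C)(C)c1cc(CNC(=O)Nc2cccc3[nH]ncc23)n(-c2cccc(C(F)(F)F)c2)n1`, gives 0.3 nM
compound 3, `Cn1ncc2c(NC(=O)NCc3cc(C(C)(C)C)nn3-c3ccc(F)cc3)cccc21`, gives 4.5 nM

Compound 1 and compound 2 share one core; compound 3 carries a different core, and the difference between the two cores is not broken down here. Compound 3 stands highest of the three numbers, above compound 1 and far above compound 2, both gaps beyond the scatter.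

Within the first core, the change trifluoromethyl in place of fluoro on an aromatic carbon is measured: a 4.3-fold lower number from compound 1 to compound 2 (0.64 log units; beyond the scatter). The same kind of change is made from compound 3 to compound 4, `Cn1ncc2c(NC(=O)NCc3cc(C(C)(C)C)nn3-c3ccc(C(F)(F)F)cc3)cccc21`, as trifluoromethyl in place of fluoro on an aromatic carbon. The two places are not the same word for word: in the pair from compound 1 to compound 2 the group sits meta to a large group, whereas in the pair from compound 3 to compound 4 it sits para to a large group, so the change is of the same kind rather than the same.

Among the measured compounds shown here, only this one earlier step is available, and it rests on a different core and a different place on the ring, so the transfer is uncertain. Compound 4 is expected to fall below compound 3 by about a 3.0-fold lower number from compound 3 to compound 4 (0.48 log units; beyond the scatter), a somewhat smaller step than the one measured, because a 4.3-fold lower number from compound 1 to compound 2 (0.64 log units; beyond the scatter) came from another core. The estimate for compound 4 in this assay is 1.5 nM, with a likely range from 0.5 nM to 4.5 nM.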

Compound 4, inhibition constant: 12.4 nM
For compound 4 the middle estimate is 8.3-fold (0.92 log units) below the measured one; measured number above the stated range.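

In this assay, trifluoromethyl in place of fluoro does not keep its direction on moving to the core of compound 3, where the result is a 2.8-fold higher number from compound 3 to compound 4 (0.44 log units; beyond the scatter). Set beside the earlier pair, the gain seen on the core of compound 1 does not transfer as a fixed step, and the two results differ in direction: the same change on two cores in this assay, a 4.3-fold lower number (0.64 log units; beyond the scatter) from compound 1 to compound 2 and a 2.8-fold higher number (0.44 log units; beyond the scatter) from compound 3 to compound 4, 12-fold (1.08 log units) apart, beyond the scatter of two such steps This does not show that the core alone decides the outcome, since the two pairs differ both in core and in where the group sits on the aromatic ring, and two pairs give no rule for any further core.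

Still open, as far as these compounds go, is how the same change behaves with the position held constant, for example on the core of compound 1 with the group para to a large group, which would separate the effect of the place from that of the core. Also open, from the compounds shown here alone, is whether other groups at that place on the ring, such as chloro, methoxy or nitrile, follow compound 3 or compound 4 on this core, or show the same reversal between the two cores.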